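The source may hold more compounds than are shown below. What is called first, only, known or untested is meant among the compounds shown, and "the series" means these compounds.

The compounds measured so far:
compound 1 `CCOc1cccc(-c2ccc(C(=O)N(Cc3cccc(OCCCCCC(=O)O)c3)C(C)C)cc2)c1`, > 20800 nM
compound 2 `CCOC(=O)CCCCCOc1cccc(CN(C(=O)c2ccc(-c3cnc(OC)nc3OC)cc2)C(C)C)c1`, > 26000 nM

Both compounds were tested in an ADME assay on HEK293 cells (Homo sapiens) for cytotoxicity, read by CellTiter-Glo and resazurin assay, with a stated time of 72 h; on this read-out lower numbers stand for an effect already at smaller amounts and higher numbers for an effect only at larger amounts of compound. For compound 2 the result is a limit of the assay, > 26000 nM, not a number. Compound 1 likewise reached only a limit, > 20800 nM. For the measured compounds named here, the two values therefore show no more than that neither compound produced a half-maximal effect within the tested range; no step between them can be counted. Going by the values given here, compound 2 stands at the limit of > 26000 nM in this assay, at which 1 of the 2 values shown sits, while the only other value sits at the limit of > 20800 nM in this assay, at which 1 of the 2 values shown sits.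

Compound 3 `CCOC(=O)CCCCCOc1cccc(CN(C(=O)c2ccc(-c3ccc4c(c3)OCCO4)cc2)C(C)C)c1` is not yet measured. It differs from compound 2 at one place: 2,3-dihydro-1,4-benzodioxin-6-yl in place of 2,4-dimethoxypyrimidin-5-yl on an aromatic carbon. Among the compounds with values here, no measured step accompanies this change, so nothing in the data speaks for a shift in either direction. In this assay the account expects no step beyond the usual scatter, and most probably once again a limit rather than a number. The estimate for compound 3 is 30000 nM, with a range from 10000 nM to 100000 nM. That estimate means a step that the limit leaves unreadable from compound 2 to compound 3.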

Compound 3, half-maximal effective concentration: > 24400 nM
Compound 3 was reported as a limit (the forecaster's own chance of this, stated with the estimate: 80%); the middle value lies beyond the limit too.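

In this assay compound 3 gives > 24400 nM, which is a limit of the assay and not a number. For the compounds shown here, compound 2 likewise gives only a limit, > 26000 nM, so no step between the two can be read. The compounds shown leave open whether 2,3-dihydro-1,4-benzodioxin-6-yl in place of 2,4-dimethoxypyrimidin-5-yl changes the read-out at all, and at what concentration any of them would reach a half-maximal effect.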